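A few compounds are considered here, and "the series" means these few. Any claim that something is new, unique, unknown or untested is made for them only; others in the source may bear on it.

Working notes on the series. In an ADME assay on BCBL1 cells (Homo sapiens) for cytotoxicity, with a stated time of 7 days (on this read-out lower numbers stand for higher toxicity in this test and higher numbers for lower toxicity in this test), compound 1 `Nc1nc(N2CCCC2)c2ncn(/C=C3/CC3(CO)CO)c2n1` reaches only the limit > 20000 nM. Compound 2 `CSc1nc(N)nc2c1ncn2/C=C1/CC1(CO)CO` likewise gives in this assay only the limit > 20000 nM. Compound 3 `Nc1nc(SC2CCCC2)c2ncn(/C=C3/CC3(CO)CO)c2n1` ends in this assay at the limit > 20000 nM as well. All three values therefore sit at the limit of > 20000 nM in this assay, at which 3 of the 3 values shown sit, and the steps a step that the two limits leave unreadable from compound 1 to compound 2, a step that the two limits leave unreadable from compound 1 to compound 3 and a step that the two limits leave unreadable from compound 2 to compound 3 cannot be read. Compound 3 thus stands only at a limit, and the two other values shown are limits too; no ordering among the three can be stated.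

Compound 4 `CC(C)Nc1nc(N)nc2c1ncn2/C=C1/CC1(CO)CO` has not been measured. It differs from compound 3 by isopropylamino in place of cyclopentylsulfanyl on an aromatic carbon. The two steps that changed the same aromatic carbon, a step that the two limits leave unreadable from compound 1 to compound 2 and a step that the two limits leave unreadable from compound 1 to compound 3, bear on this exchange, but neither has a readable size, so no direction for the new step can be drawn from them. The expectation in this assay for compound 4 is therefore no step beyond the scatter, a step that the limit leaves unreadable from compound 3 to compound 4, with a good chance that only a limit is reported again. The estimate for compound 4 in this assay is 30000 nM, within a range from 12000 nM to 100000 nM.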

Compound 4, half-maximal cytotoxic concentration: > 20000 nM
Compound 4: a limit, no number; the forecaster's own chance of this, stated with the estimate: 80%; the middle value is on the limit's open side.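

In this assay compound 4 gives only a limit, > 20000 nM, and the steps to compound 4 from compound 1, compound 2 and compound 3 cannot be read. All values shown rest on the same limit: the limit of > 20000 nM in this assay, at which 4 of the 4 values shown sit. The compounds shown leave open whether exchanging the group on this aromatic carbon alters the read-out at all, and in which direction.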